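The source may hold more compounds than are shown below. What is called first, only, known or untested is meant among the compounds shown, and "the series" means these compounds.

Working notes on the series. Compound 1 `C[C@]1(C(=O)N2CC[C@](c3ccc(C(F)(C(F)(F)F)C(F)(F)F)cc3)(S(=O)(=O)c3ccc(F)cc3)C2)CC[C@H](C(=O)O)CC1` and compound 2 `CO[C@]1(C(=O)N2CC[C@](c3ccc(C(F)(C(F)(F)F)C(F)(F)F)cc3)(S(=O)(=O)c3ccc(F)cc3)C2)CC[C@H](C(=O)O)CC1` share the common core and differ only in methoxy in place of methyl on a saturated ring carbon. In an ADME assay on microsomes from liver (Homo sapiens) for metabolic stability, with a stated time of 10 min (a higher number here means that more of the compound is left, a lower number that less of the compound is left), compound 1 gives 80%, and compound 2 gives 82%. The step between them: a number 2 percentage points higher from compound 1 to compound 2 (within the scatter).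

Compound 3 `O=C(N1CC[C@](c2ccc(C(F)(C(F)(F)F)C(F)(F)F)cc2)(S(=O)(=O)c2ccc(F)cc2)C1)C12CCC(C(=O)O)(CC1)OC2` carries a different group on the carbonyl carbon. In this assay compound 3 gives "not determined" (no result reported), so it stands without a number on this read-out. Compound 4 `O=C(N1CC[C@](c2ccc(C(F)(C(F)(F)F)C(F)(F)F)cc2)(S(=O)(=O)c2ccc(F)cc2)C1)C1(CO)CCS(=O)(=O)CC1` is the next member to be measured. Change from compound 3 to compound 4: a group of 10 heavy atoms (6 carbon, 3 oxygen, 1 sulfur; one six-membered non-aromatic ring with 1 hetero atom) in place of a group of 11 heavy atoms (8 carbon, 3 oxygen; one six-membered non-aromatic ring of carbon only, one six-membered non-aromatic ring with 1 hetero atom), on a carbonyl carbon.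

Going by the values given here, the only measured step, a number 2 percentage points higher from compound 1 to compound 2 (within the scatter), concerns an exchange on a saturated ring carbon and not the exchange of the whole group on the carbonyl carbon, so no step in hand bears directly on the change to compound 4, and compound 3 offers no starting number. What can be said is that both measured members, compound 1 at 80% and compound 2 at 82%, sit close together in this assay. For compound 4 the expectation in this assay is therefore taken from that region with a wide band: 75%, estimated to fall between 55% and 92%.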

Compound 4, percent of the compound remaining: 75%
Estimate against measurement, compound 4: no gap at the digits printed, and the stated range covers the measured number.
By their numbers in this assay, from the lowest: compounds 4, 1 and 2 (each within the scatter of the next).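

Working notes, continued. The exchange of the whole group on the carbonyl carbon can now be read in this assay: 4-(hydroxymethyl)-1,1-dioxothian-4-yl in place of 4-carboxy-1-methoxycyclohexyl gives (a number 7 percentage points lower from compound 2 to compound 4 (within the scatter)), and in place of 4-carboxy-1-methylcyclohexyl it gives (a number 5 percentage points lower from compound 1 to compound 4 (within the scatter)). Where the earlier comparison covered only methoxy in place of methyl on a saturated ring carbon, these steps show that, for compounds 1, 2 and 4, this read-out does not separate the two carboxy-bearing cyclohexyl groups from a hydroxymethyl-bearing ring that holds a hetero atom. Nothing at hand speaks to what lies behind this result.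

Compound 3 has no number in this assay, and its step to compound 4 cannot be read. Also open is whether the read-out would hold with an amine in place of the hydroxymethyl on the same ring, or with an open longer chain in place of the ring on the carbonyl carbon, and the compounds shown cannot say which part of the entering group, the hydroxymethyl or the ring, matters here.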